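Moving the chlorine around the phenyl ring

The source may hold more compounds than are shown below. What is called first, only, known or untested is meant among the compounds shown, and "the series" means these compounds.

The measured compounds:
compound 1, `Cn1c(-c2cccc(Cl)c2)nc2c(NC3CCCC3)ncnc21`, 2530 nM
compound 2, `Cc1ccccc1-c1nc2c(NC3CCCC3)ncnc2n1C`, a limit, > 30000 nM
compound 3, `Cn1c(-c2ccc(Cl)cc2)nc2c(NC3CCCC3)ncnc21`, a limit, > 30000 nM

All three share one core and differ only in the aryl group on the five-membered ring. They were tested in a functional assay on CHO cells for antagonist activity at adenosine receptor A2b (Homo sapiens), read by 33P incorporation, with a stated time of 20 min; a higher number here means a weaker inhibitor, a lower number a stronger inhibitor. Compound 1, with 3-chlorophenyl, gives a number, 2530 nM. Compound 3 sits at the limit of this assay, so no number is known for it. Compound 2 sits at that same limit. Two of the three values therefore rest at the limit of > 30000 nM in this assay, at which 2 of the 3 values shown sit.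

The step of an at least 11-fold higher number from compound 1 to compound 3 (1.07 log units; beyond the scatter) and the step of an at least 11-fold higher number from compound 1 to compound 2 (1.07 log units; beyond the scatter) both show that leaving 3-chlorophenyl costs a great deal of potency. The step that the two limits leave unreadable from compound 2 to compound 3 cannot be read, since both ends are limits.

Compound 4, `Cn1c(-c2ccccc2Cl)nc2c(NC3CCCC3)ncnc21`, has not yet been tested. It differs from compound 3 by 2-chlorophenyl in place of 4-chlorophenyl on an aromatic carbon. The chlorine moves to the position held by the methyl in compound 2, and compound 2 reached only the limit. Compound 4 is therefore expected to be weak as well, with the step of an at least 1.2-fold lower number from compound 3 to compound 4 (0.07 log units; that floor lies within the scatter) estimated at about nothing readable. The expected value for compound 4 is 25000 nM, within 5000 nM to 120000 nM.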

Compound 4, inhibition constant: > 30000 nM
Compound 4 was reported as a limit (the forecaster's own chance of this, stated with the estimate: 60%); middle value at least 1.2-fold (0.07 log units) from the limit.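

Compound 4 is reported in this assay as > 30000 nM, which is a limit of the assay and not a number. Placing the chlorine as in 2-chlorophenyl brings an at least 11-fold higher number from compound 1 to compound 4 (1.07 log units; beyond the scatter), so among the three chlorophenyl compounds, which hold the same atoms joined differently, only the 3-chlorophenyl of compound 1 gives a number. The steps among compound 2, compound 3 and compound 4 cannot be read, as both ends of each are limits, so these three cannot be put in any order: the limit of > 30000 nM in this assay, at which 3 of the 4 values shown sit.

The compounds shown leave open whether the number for compound 1 depends on chlorine itself, or whether a methoxy group or an amine in place of that chlorine on the phenyl ring would also give one. They also leave open how far past the limit compound 2, compound 3 and compound 4 lie, and whether they differ from one another at all.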